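The compounds below may be only part of what the source reports. "The series", "measured", "known", "first", "only" and "open" are said of these compounds alone.

Compound 1 `COc1ccc(O)c(CSc2ccccc2)c1` gives 590 nM in a functional assay for inhibition, with Homo sapiens as the target; a lower number here means a stronger inhibitor, a higher number a weaker inhibitor.
Compound 2 `COc1ccc(O)c(CSc2ccccc2CO)c1` gives 8700 nM in this assay.
Compound 3 `Oc1cc2c(cc1CNc1ccccc1)OCCC2` gives 1700 nM in this assay.

Compound 1 and compound 2 differ by one change, (hydroxymethyl in place of hydrogen on an aromatic carbon), and it made a step of a 15-fold higher number from compound 1 to compound 2 (1.17 log units; beyond the scatter). Compound 3 sits between the two, and its core differs from that of compound 1 in a way that is not broken down here. Compound 4 `OCc1ccccc1NCc1cc2c(cc1O)CCCO2` has not yet been measured; it differs from compound 3 by hydroxymethyl in place of hydrogen on an aromatic carbon, the same change that was made between compound 1 and compound 2. On the basis of that change, compound 4 is expected to be a weaker inhibitor than compound 3 by a step of about a 10-fold higher number from compound 3 to compound 4 (1.00 log units; beyond the scatter), because the same change gave a 15-fold higher number from compound 1 to compound 2 (1.17 log units; beyond the scatter), though the cores differ and the step may not carry over fully. Compound 4 is estimated at 17000 nM, within 5000 nM to 60000 nM.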

Compound 4, half-maximal inhibitory concentration: 21000 nM
For compound 4 the middle estimate is 1.2-fold (0.09 log units) below the measured one; measured number inside the range.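

In this assay, hydroxymethyl in place of hydrogen on an aromatic carbon gave a 12-fold higher number from compound 3 to compound 4 (1.09 log units; beyond the scatter), so the change weakened inhibition on this core as well, and by a similar amount to the earlier step: the same change on two cores in this assay, a 15-fold higher number (1.17 log units; beyond the scatter) from compound 1 to compound 2 and a 12-fold higher number (1.09 log units; beyond the scatter) from compound 3 to compound 4, 1.2-fold (0.08 log units) apart, within the scatter of two such steps. For these two pairs, then, the size of the step carried over from the core of compound 1 to the core of compound 3. Two pairs in a single assay do not show that it would carry over to any other core, and they do not explain why the number rises.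

The compounds shown leave open whether the step is specific to hydroxymethyl. A methoxy group, a carboxylic acid, an aminomethyl group or a longer chain such as hydroxyethyl on that same aromatic carbon could give a different result.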